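The source may report more compounds than this note shows. Statements on the series, on what has been measured and on what is new or still open speak of the compounds shown alone.

Working notes on a cathepsin S series.

For the measured compounds named here, compound 1 `CCCC[C@H](NC(=O)O[C@H](Cn1cnc(-c2ccc(C(F)(F)F)cc2)c1)C(C)(C)C)C(=O)C(=O)Nc1ccn[nH]1` and compound 2 `CCCC[C@H](NC(=O)O[C@H](Cn1ccc(-c2ccc(C(F)(F)F)cc2)n1)C(C)(C)C)C(=O)C(=O)Nc1ccccn1` differ in more than one place, so no single step is drawn between them. In an assay on isolated protein for binding affinity to cathepsin S (Homo sapiens), read by fluorescence (a higher number here means a weaker inhibitor, a lower number a stronger inhibitor), compound 1 gives 160 nM, while compound 2 gives 3700 nM. Going by the values given here, compound 2 thus stands with the highest of the two numbers so far, the gap to compound 1 lying beyond the scatter.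

Compound 3 `CCCC[C@H](NC(=O)O[C@H](Cn1ccc(-c2ccc(C(F)(F)F)cc2)n1)C(C)(C)C)C(=O)C(=O)NCc1ccno1` has not yet been measured in this assay. It comes out of compound 2 by one change: (1,2-oxazol-5-yl)methyl in place of pyridin-2-yl on an amide-type nitrogen. Nothing already measured separates that change on its own, so the direction of the step rests on expectation only. A small lowering of the number is expected, of a size that may not clear the scatter; the expected step from compound 2 to compound 3 in this assay is a 1.9-fold lower number from compound 2 to compound 3 (0.27 log units; within the scatter). The estimate for compound 3 in this assay is 2000 nM, with a range from 500 nM to 8000 nM.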

Compound 3, half-maximal inhibitory concentration: 19000 nM
Beside the measured number, compound 3's estimate is 9.5-fold (0.98 log units) below it; the whole stated range lies below it.
By their numbers in this assay, from the lowest: compound 1; then compound 2; then compound 3.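

In this assay, for the compounds shown here, (1,2-oxazol-5-yl)methyl in place of pyridin-2-yl on the amide-type nitrogen gives a 5.1-fold higher number from compound 2 to compound 3 (0.71 log units; beyond the scatter), the first single-place step, and it shows that the group on this nitrogen affects the number and that this exchange raises it. The heavy-atom count stays the same, so this step does not come with a change in that count, yet the exchange alters several things at once: a six-membered aromatic ring gives way to a five-membered one, the hetero atoms change, the hydrogen-bond acceptor count goes from 1 to 2, and a methyl link now stands on the nitrogen. Nothing available bears on which of these differences accounts for the rise.

The compounds shown leave open whether the ring or the methyl link carries the step; a directly attached 1,2-oxazol-5-yl or a (pyridin-2-yl)methyl group on the same nitrogen would separate the two. Also open, as far as these compounds go, is whether the same exchange moves the number in the same direction on the core of compound 1, and how a simple benzyl or a plain alkyl chain at this position would read.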